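The compounds below may be only part of what the source reports. "The series", "measured", "known", "first", "only" and "open" are said of these compounds alone.

Of the compounds shown here, three that share one core have been measured in a functional assay on HT-29 cells (Homo sapiens) for inhibition; on this read-out higher numbers stand for weaker inhibition of growth and lower numbers for stronger inhibition of growth. Compound 1 `COc1cc(/C=C/C(=O)c2cccc(-n3cc(-c4ccc(Cl)cc4)[nH]c3=O)c2)cc(OC)c1OC` gives 2000 nM. Compound 2 `COc1cc(/C=C/C(=O)c2cccc(-n3cc(-c4ccccc4)[nH]c3=O)c2)cc(OC)c1OC` gives 660 nM. Compound 3 `COc1ccc(-c2cn(-c3cccc(C(=O)/C=C/c4cc(OC)c(OC)c(OC)c4)c3)c(=O)[nH]2)cc1` gives 1280 nM. The number for compound 3 is the second highest of the three, but its gaps to both neighbours lie within the scatter: the change from compound 1 to compound 3 amounted to a 1.6-fold lower number from compound 1 to compound 3 (0.19 log units; within the scatter), and the change from compound 2 to compound 3 to a 1.9-fold higher number from compound 2 to compound 3 (0.29 log units; within the scatter). Among the compounds with values here, only the step from compound 1 to compound 2, at a 3.0-fold lower number from compound 1 to compound 2 (0.48 log units; beyond the scatter), went beyond the scatter.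

Compound 4 `COc1cc(/C=C/C(=O)c2cccc(-n3cc(-c4cc(OC)c(OC)c(OC)c4)[nH]c3=O)c2)cc(OC)c1OC` has not yet been measured in this assay. It differs from compound 3 by 3,4,5-trimethoxyphenyl in place of 4-methoxyphenyl on an aromatic carbon. The measured steps that bear on this change are the two that altered the same aromatic carbon by introducing a methoxy: from compound 2 to compound 3 (a 1.9-fold higher number from compound 2 to compound 3 (0.29 log units; within the scatter)) and from compound 1 to compound 3 (a 1.6-fold lower number from compound 1 to compound 3 (0.19 log units; within the scatter)), both within the scatter. Because the changes at this carbon came to a 1.9-fold higher number from compound 2 to compound 3 (0.29 log units; within the scatter) and a 1.6-fold lower number from compound 1 to compound 3 (0.19 log units; within the scatter) and thus stayed within the scatter, the step from compound 3 to compound 4 in this assay is expected to be small in either direction, a 1.1-fold higher number from compound 3 to compound 4 (0.04 log units; within the scatter). Compound 4 is therefore estimated at 1400 nM, with a range from 500 nM to 4000 nM.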

Compound 4, concentration for 50% growth inhibition: 1700 nM
Compound 4: the middle estimate sits 1.2-fold (0.08 log units) below what was measured; the range from low to high includes it.
By their numbers in this assay, from the lowest: compounds 2, 3, 4 and 1 (each within the scatter of the next, the first and the last beyond it).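

In this assay replacing 4-methoxyphenyl with 3,4,5-trimethoxyphenyl, which has 12 heavy atoms in place of 8 and 3 hydrogen-bond acceptors in place of 1, leaves the read-out within the scatter (a 1.3-fold higher number from compound 3 to compound 4 (0.12 log units; within the scatter)), so this aromatic carbon carries the larger group with no change that can be read. Set against the plain phenyl group, however, the same trimethoxyphenyl group gives a step beyond the scatter (a 2.6-fold higher number from compound 2 to compound 4 (0.41 log units; beyond the scatter)), while against 4-chlorophenyl it stays within the scatter (a 1.2-fold lower number from compound 1 to compound 4 (0.07 log units; within the scatter)). Compound 2 with its plain phenyl is now separated from two substituted compounds rather than one, giving a modest trend towards higher numbers with substitution on this phenyl ring, although compound 3 goes against it by staying within the scatter of compound 2.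

Nothing available here explains why these groups read as they do. The compounds shown carry only chloro and methoxy on this phenyl ring, so it remains open how an amine, a carboxylic acid or a longer chain would read at this position.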